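Benzotriazine dioxide amines: aryl extension on the methylene linker

The source may report more compounds than this note shows. Statements on the series, on what has been measured and on what is new or still open speak of the compounds shown alone.

Measured compounds:
- compound 1, `COCNc1n[n+]([O-])c2ccccc2[n+]1[O-]`: 2770 nM
- compound 2, `COc1ccc2c(c1)[n+]([O-])nc(NCOCc1ccccc1)[n+]2[O-]`: 4470 nM

In a functional assay on A549 cells (Homo sapiens) for cytotoxicity, read by MTT assay, with a stated time of 72 h (a lower number here means a stronger inhibitor, a higher number a weaker inhibitor), compound 1 gives 2770 nM. Its nearest neighbour is compound 2, which in this assay gives 4470 nM; compound 1 is numerically the lower of the two numbers, but the gap to compound 2 falls within the scatter, so the two are not separated. Among the measured compounds shown here, compound 2 also differs from compound 1 in more than one place, and no single step between measured compounds is available.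

Compound 3, `COc1ccc(COCNc2n[n+]([O-])c3ccccc3[n+]2[O-])cc1`, is not yet measured in this assay. Relative to compound 1 the change is 4-methoxyphenyl in place of hydrogen on a saturated chain carbon bound to an oxygen on a saturated carbon. For the measured compounds named here, the only guide is that compound 2, which carries a related aryl extension on the same linker together with a change on the core, sits within the scatter of compound 1. Going by the values given here, with no step isolating the aryl group alone, the expectation for the step of a 1.3-fold higher number from compound 1 to compound 3 (0.10 log units; within the scatter) is a small one, not beyond the scatter, in either direction. Compound 3 is therefore estimated at 3500 nM in this assay, with a range of 1400 nM to 9000 nM.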

Compound 3, half-maximal inhibitory concentration: 3320 nM
Beside the measured number, compound 3's estimate is 1.1-fold (0.02 log units) above it; low and high end bracket the measured number.
By their numbers in this assay, from the lowest: compounds 1, 3 and 2 (each within the scatter of the next).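

The aryl extension can now be read on its own. In this assay, 4-methoxyphenyl in place of hydrogen on a saturated chain carbon bound to an oxygen on a saturated carbon gives a 1.2-fold higher number from compound 1 to compound 3 (0.08 log units; within the scatter) on an otherwise unchanged core, so adding this group of 8 heavy atoms, including one six-membered aromatic ring, at this position produces no change that can be separated from the scatter. Compound 2 could not show this, as it differs from compound 1 in more than one place, and no information bears on why the step is so small.

This single step says nothing about other groups at this place: an amine, a carboxylic acid or a longer chain could still separate from compound 1 in either direction. The contribution of a methoxy group on the core also remains open, as the compounds shown contain no single step that isolates it, and one flat step on one cell line does not establish a trend for the series.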